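A Cyclic Urea Replaces the Triazolylmethyl Side Group

The source may report more compounds than this note shows. Statements on the series, on what has been measured and on what is new or still open speak of the compounds shown alone.

Compound 1, `CC(C)C(Cc1nnc[nH]1)c1ccc(-c2ccc3cccc(F)c3c2)[nH]c1=O`: 0.1 h
Compound 2, `Cc1nc(C(c2ccc(-c3ccc4cccc(F)c4c3)[nH]c2=O)C(C)C)[nH]c1C`: 0.0733 h
Compound 3, `CC(C)C(c1noc(=O)[nH]1)c1ccc(-c2ccc3cccc(F)c3c2)[nH]c1=O`: > 3 h

In an ADME assay on microsomes from liver (Rattus norvegicus) for metabolic stability (a higher number here means that the compound lasts longer, a lower number that the compound disappears faster), compound 1 gives 0.1 h. Compound 2 gives 0.0733 h, and the step of a 1.4-fold lower number from compound 1 to compound 2 (0.13 log units; within the scatter) shows the two compounds cannot be told apart. For compound 3 the result is a limit of the assay, (the limit of > 3 h in this assay, at which 1 of the 3 values shown sits), not a number. Within the data shown here, the step of an at least 30-fold higher number from compound 1 to compound 3 (1.47 log units; beyond the scatter) is therefore a large gain in half-life, the only change in this set that moves the read-out.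

Compound 4, `CC(C)C(c1ccc(-c2ccc3cccc(F)c3c2)[nH]c1=O)N1CCNC1=O`, is not yet measured. It differs from compound 1 in one place: 2-oxoimidazolidin-1-yl in place of (4H-1,2,4-triazol-3-yl)methyl on a saturated chain carbon bound to an aromatic carbon and a saturated chain carbon. The two measured steps leaving compound 1 point in different directions. Swapping the side group for another five-membered aromatic ring with 2 hetero atoms changed nothing, while swapping it for a five-membered aromatic ring with 3 hetero atoms and two oxygens gave a large gain. The 2-oxoimidazolidin-1-yl group brings a one five-membered non-aromatic ring with 2 hetero atoms and a carbonyl, which neither measured step covers directly. A modest gain seems the most reasonable expectation, with wide uncertainty. Compound 4 is therefore expected to give about 0.3 h in this assay, a step of a 3.0-fold higher number from compound 1 to compound 4 (0.48 log units; beyond the scatter), with a range from 0.08 h to 1.5 h.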

Compound 4, half-life: 0.283 h
Estimate against measurement, compound 4: 1.1-fold (0.03 log units) above, within the range that was stated.
By their numbers in this assay, from the lowest: compounds 2 and 1 (each within the scatter of the next); then compound 4. At a limit, above all of these: compound 3.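

In this assay, a change at this saturated chain carbon now gives a readable gain without an aromatic ring in the side group, as 2-oxoimidazolidin-1-yl brings a 2.8-fold higher number from compound 1 to compound 4 (0.45 log units; beyond the scatter) and also a 3.9-fold higher number from compound 2 to compound 4 (0.59 log units; beyond the scatter). This non-aromatic ring therefore lies clearly apart from the two aromatic side groups of the short-lived pair, yet it falls well short of the ring in compound 3, with an at least 10-fold lower number from compound 3 to compound 4 (1.02 log units; beyond the scatter), so groups of the same heavy-atom count at this place can still differ widely. The result for compound 3 is a limit of the assay and not a number: the limit of > 3 h in this assay, at which 1 of the 4 values shown sits.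

The two side groups that give the longer half-lives both carry a carbonyl, but the compounds shown cannot separate the part played by that carbonyl from the part played by the rest of each ring. From the compounds shown here alone, how a pyrrolidin-1-yl ring, which lacks the carbonyl, or an open-chain urea would behave at this same place remains open, as does how far the half-life of compound 4 could be raised with small changes to its ring.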